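Notes on the step from compound 1 to compound 3

The source may report more compounds than this note shows. Statements on the series, on what has been measured and on what is new or still open speak of the compounds shown alone.

In a physicochemical assay for lipophilicity, read by HPLC, at pH 7.5 (a lower number here means a more polar compound, a higher number a more lipophilic compound), compound 1 (`CC[C@@H](Nc1c(C#N)c(-c2ccc(-c3ccc(F)cc3)cc2)nc2cnccc12)C(N)=O`) gives 2.7 as the higher of two measured values. Compound 2 (`CN(CC(N)=O)c1c(C#N)c(-c2ccc(Br)cc2)nc2cnccc12`) gives 2.1 and so lies lower, beyond the usual scatter. Going by the values given here, no measured pair differs in one place only, so the expectation below rests on the structural change alone. Compound 3 (`CC[C@@H](Nc1c(C#N)c(-c2ccc(-c3cccnc3C)cc2)nc2cnccc12)C(N)=O`) has 2-methylpyridin-3-yl in place of 4-fluorophenyl on an aromatic carbon para to a large group. A fall in this assay is expected, with a number 0.60 log units lower from compound 1 to compound 3 (beyond the scatter) as the estimated step, beyond the scatter. For compound 3 the estimate is 2.1 with an expected range of 1.7 to 2.5 in this working note.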

Compound 3, distribution coefficient: 1.9
The estimate for compound 3 lay 0.20 log units above the measured number; low and high end bracket the measured number.
By their numbers in this assay, from the lowest: compounds 3 and 2 (each within the scatter of the next); then compound 1.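

In this assay, going by these compounds alone, 2-methylpyridin-3-yl in place of 4-fluorophenyl on this aromatic carbon gives a number 0.80 log units lower from compound 1 to compound 3 (beyond the scatter), the only step here between compounds that differ in one place. This position therefore responds to the change, with the heavy-atom count unchanged and one hydrogen-bond acceptor entering. No measurement shown accounts for the size of this step. On these data alone, how the step divides between the ring nitrogen and the methyl remains open. So does the response of this position to an unsubstituted phenyl, an amine or a carboxylic acid.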